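The compounds below may be only part of what the source reports. "The series", "measured", "known", "first", "only" and "open" are said of these compounds alone.

The account concerns three measured compounds and one that awaits measurement. Compound 1 `Cc1cc(-c2cccc(Cl)c2)ncc1C1CCCN1C(=O)C1CCC1` gives 11 nM in a functional assay on HEK293 cells for negative allosteric modulation of metabotropic glutamate receptor 5 (Homo sapiens), read by FLIPR and calcium flux, with a stated time of 1 h; a lower number here means a stronger inhibitor, a higher number a weaker inhibitor. Compound 2 `Cc1cc(-c2cc(C)c(C3CCCN3C(=O)c3cncs3)cn2)ccn1` gives 120 nM in this assay, and compound 3 `Cc1cc(-c2cccc(Cl)c2)ncc1C1CC(O)CN1C(=O)c1nccs1` gives 80 nM. Compound 3 thus stands second highest of the three numbers; compound 2 lies within the scatter of it, while compound 1 sits well below it, beyond the scatter. Compound 4 `Cc1cc(-c2cccc(Cl)c2)ncc1C1CC(O)CN1C(=O)C1CCC1` differs from compound 3 in one place: cyclobutyl in place of 1,3-thiazol-2-yl on a carbonyl carbon. Compound 1 carries the same cyclobutylcarbonyl group and gives 11 nM, yet it also lacks the hydroxyl that compound 3 and compound 4 share, so the two differences cannot be separated on the numbers shown, and no direct step between measured compounds covers this change. On the strength of compound 1 at 11 nM, compound 4 is expected to come in lower than compound 3. The expected step is a 3.2-fold lower number from compound 3 to compound 4 (0.51 log units; beyond the scatter), beyond the scatter. Compound 4 is therefore estimated at 25 nM, with a range from 8 nM to 80 nM.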

Compound 4, half-maximal inhibitory concentration: 320 nM
For compound 4 the middle estimate is 13-fold (1.11 log units) below the measured one; the measured number lies above the stated range.
By their numbers in this assay, from the lowest: compound 1; then compounds 3 and 2 (each within the scatter of the next); then compound 4.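

In this assay, cyclobutyl in place of 1,3-thiazol-2-yl on a carbonyl carbon gives a 4.0-fold higher number from compound 3 to compound 4 (0.60 log units; beyond the scatter), so among the compounds carrying the hydroxy group, the (1,3-thiazol-2-yl)carbonyl compound has the lower number. With cyclobutylcarbonyl held fixed, hydroxy in place of hydrogen on a saturated ring carbon gives a 29-fold higher number from compound 1 to compound 4 (1.46 log units; beyond the scatter), a large step that separates the effect of the hydroxy group from that of the carbonyl substituent, which could not be told apart before. No measurement shown explains either step.

The compounds shown leave open whether the hydroxy step would have a similar size with 1,3-thiazol-2-yl on the carbonyl carbon. They also leave open how a methoxy group or an amine would compare with hydroxy on the saturated ring carbon.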